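The source may report more compounds than this note shows. Statements on the series, on what has been measured and on what is new or still open speak of the compounds shown alone.

Measured compounds:
compound 1 `COc1ccc(C2=C(c3cc(OC)c(OC)c(OC)c3)C(=O)C(O)C2)cc1`: < 1 ug/mL
compound 2 `COc1ccc(C2=C(c3cc(OC)c(OC)c(OC)c3)CC(O)C2=O)cc1[N+](=O)[O-]`: > 100 ug/mL
compound 3 `COc1ccc(C2=C(c3cc(OC)c(OC)c(OC)c3)C(=O)C(O[SiH2]C(C)(C)C)C2)cc1`: 16 ug/mL

In an ADME assay on ECV-304 cells (Homo sapiens) for cytotoxicity, read by MTT assay, with a stated time of 72 h (on this read-out lower numbers stand for stronger inhibition and higher numbers for weaker inhibition), compound 1 gives < 1 ug/mL, which is a limit of the assay (the limit of < 1 ug/mL in this assay, at which 1 of the 3 values shown sits). Compound 2 gives > 100 ug/mL, again only a limit (the limit of > 100 ug/mL in this assay, at which 1 of the 3 values shown sits). Compound 3 gives 16 ug/mL. The change from compound 1 to compound 3, (a group of 5 heavy atoms (4 carbon, 1 silicon; no ring) in place of a hydrogen atom, on an oxygen on a saturated carbon), produced an at least 16-fold higher number from compound 1 to compound 3 (1.20 log units; beyond the scatter). The difference between the cores of compound 1 and compound 2 is not broken down here. Compound 4 `COc1ccc(C2=C(c3cc(OC)c(OC)c(OC)c3)CC(O[SiH2]C(C)(C)C)C2=O)cc1[N+](=O)[O-]` carries the same change on the core of compound 2: a group of 5 heavy atoms (4 carbon, 1 silicon; no ring) in place of a hydrogen atom, on an oxygen on a saturated carbon. Compound 2 already sits at a limit, and the earlier step of an at least 16-fold higher number from compound 1 to compound 3 (1.20 log units; beyond the scatter) moved the number upward, so compound 4 is expected to stay at or beyond that limit, a step that the limit leaves unreadable from compound 2 to compound 4. Compound 4 is estimated at 150 ug/mL, within 60 ug/mL to 400 ug/mL.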

Compound 4, half-maximal inhibitory concentration: > 100 ug/mL
Compound 4: a limit, no number (the forecaster's own chance of this, stated with the estimate: 80%); the middle value does not contradict the limit.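

Compound 4 gives > 100 ug/mL in this assay, which is a limit of the assay. Compound 2 also sits at a limit, so the step from compound 2 to compound 4 cannot be read. The compounds shown leave open whether this silicon-containing group changes the number at all on the core of compound 2.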